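The compounds below may be only part of what the source reports. "The series", "measured", "known", "first", "only" and "open" are said of these compounds alone.

Among the compounds with values here, two ureas on the shared core have numbers so far. Compound 1 `O=C(Nc1ccccc1)Nc1ccc2c(c1)COC2=O` in a functional assay on cells (T-cell, Mus musculus) for inhibition (a lower number here means a stronger inhibitor, a higher number a weaker inhibitor), gives 7090 nM. Compound 2 `Cc1ccccc1NC(=O)Nc1ccc2c(c1)COC2=O` in this assay gives 900 nM, and the step of a 7.9-fold lower number from compound 1 to compound 2 (0.90 log units; beyond the scatter) is the only one measured in the set. On these two numbers compound 2 stands lowest, with compound 1 the nearest and the only other point, a step beyond the scatter away.

Compound 3 `Cc1cccc(NC(=O)Nc2ccc3c(c2)COC3=O)c1` is the next member. The difference is 3-methylphenyl in place of 2-methylphenyl on an amide-type nitrogen; the two have the same atoms, joined differently. Within the data shown here, the one measured step bears on it only loosely: it tells that a methyl on the phenyl helps relative to hydrogen, but nothing about where on that ring the methyl sits, since both methyl placements are so far represented by a single compound each, compound 2 measured and compound 3 not. Among the measured compounds shown here, no step in hand therefore fixes a direction, and the expectation is a change that stays within the usual scatter, with the range widened to allow either side.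

Compound 3 is expected to give 1500 nM, between 400 nM and 5000 nM. The expected step of a 1.7-fold higher number from compound 2 to compound 3 (0.22 log units; within the scatter) lies within the scatter.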

Compound 3, half-maximal inhibitory concentration: 2260 nM
Beside the measured number, compound 3's estimate is 1.5-fold (0.18 log units) below it, within the range that was stated.
By their numbers in this assay, from the lowest: compound 2; then compound 3; then compound 1.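

In this assay, the methyl on the phenyl group counts through its placement as well as its presence: 3-methylphenyl in place of 2-methylphenyl on the amide-type nitrogen gives a 2.5-fold higher number from compound 2 to compound 3 (0.40 log units; beyond the scatter), even though the group that leaves and the group that enters match in every count computed for them. The methyl of compound 3 still keeps a gain over the unsubstituted phenyl, with a 3.1-fold lower number from compound 1 to compound 3 (0.50 log units; beyond the scatter), so both methyl placements improve on compound 1, and the step to compound 2 is the larger of the two. No measurement on hand accounts for the difference between the two placements.

Whether the preference for 2-methylphenyl holds for other groups remains open, since methyl is the only substituent shown on this ring, and an ethyl, a methoxy or a chlorine at the same place could follow the same order or a different one. Also open, going by these compounds, is whether a second methyl on the phenyl would add to the gain seen for compound 2 or cancel it.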